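The source may report more compounds than this note shows. Statements on the series, on what has been measured and on what is new or still open speak of the compounds shown alone.

Measured so far:

- compound 1 `Cc1ccc(CNC(=O)c2cccc(C(C)Oc3cccnc3Nc3ncccn3)c2)cc1`: > 100000 nM
- compound 2 `Cc1ccc(CNC(=O)c2cccc(C(C)Oc3cccnc3Nc3cnn(CC(C)(C)O)c3)c2)cc1`: 9100 nM
- compound 3 `Cc1ccc(CNC(=O)c2cccc(C(C)Oc3cccnc3Nc3cnn(CC#N)c3)c2)cc1`: 38400 nM

In a functional assay on NCI-H3122 cells (Homo sapiens) for antiproliferative activity, read by MTT assay, with a stated time of 48 h (on this read-out lower numbers stand for stronger inhibition and higher numbers for weaker inhibition), compound 1 reaches only the limit of the assay, (the limit of > 100000 nM in this assay, at which 1 of the 3 values shown sits), so no number is known for it. Compound 3 carries the highest of the two numbers actually measured; its nearest neighbour is compound 2, and the step of a 4.2-fold higher number from compound 2 to compound 3 (0.63 log units; beyond the scatter) lies beyond the scatter. Compound 4 `Cc1ccc(CNC(=O)c2cccc(C(C)Oc3cccnc3Nc3ncc(C)s3)c2)cc1` is not yet measured. It differs from compound 3 in one place: 5-methyl-1,3-thiazol-2-yl in place of 1-(cyanomethyl)-1H-pyrazol-4-yl on a nitrogen on an aromatic ring. Among the compounds with values here, two measured steps touch the same position, both replacing pyrimidin-2-yl: an at least 10-fold lower number from compound 1 to compound 2 (1.04 log units; beyond the scatter) and an at least 2.6-fold lower number from compound 1 to compound 3 (0.41 log units; beyond the scatter). Both show that the group on this aromatic nitrogen moves the number strongly, but neither involves a thiazolyl group, and compound 4 loses the 1-hydroxy-1-methylethyl and cyano chains that distinguished compound 2 from compound 3. The expected step of a 1.0-fold higher number from compound 3 to compound 4 (0.02 log units; within the scatter) is therefore uncertain and in either direction. Compound 4 is estimated at 40000 nM, expected between 8000 nM and 200000 nM.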

Compound 4, half-maximal inhibitory concentration: 8500 nM
For compound 4 the middle estimate is 4.7-fold (0.67 log units) above the measured one; measured number inside the range.
By their numbers in this assay, from the lowest: compounds 4 and 2 (each within the scatter of the next); then compound 3. At a limit, above all of these: compound 1.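

In this assay, replacing 1-(cyanomethyl)-1H-pyrazol-4-yl with 5-methyl-1,3-thiazol-2-yl gives a 4.5-fold lower number from compound 3 to compound 4 (0.65 log units; beyond the scatter), so this nitrogen can carry a ring other than a pyrazole, here one with sulfur and no nitrile, without a loss of activity. The comparison with the hydroxy-bearing pyrazole gives a 1.1-fold lower number from compound 2 to compound 4 (0.03 log units; within the scatter), so the 1-(2-hydroxy-2-methylpropyl)-1H-pyrazol-4-yl group and the methyl-bearing thiazole cannot be told apart in this assay. Against pyrimidin-2-yl, the thiazole gives an at least 11-fold lower number from compound 1 to compound 4 (1.07 log units; beyond the scatter), a step that rests on a limit for compound 1: the limit of > 100000 nM in this assay, at which 1 of the 4 values shown sits.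

As far as these compounds go, what the methyl on the thiazole contributes remains open, and a thiazole bearing a hydrogen, an ethyl group or an amine there would test it. The compounds shown also do not explain why pyrimidin-2-yl differs from the thiazole and the pyrazoles.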